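The source may hold more compounds than are shown below. What is called first, only, known or untested is meant among the compounds shown, and "the series" means these compounds.

Compound 2, `COc1cc2ccc(=O)oc2cc1OC(=O)c1c(-c2ccccc2)n[nH]c1C`, is the starting point. In a functional assay on SW-620 cells (Homo sapiens) for inhibition, read by MTT assay, with a stated time of 48 h (a lower number here means a stronger inhibitor, a higher number a weaker inhibitor), compound 2 gives > 25000 nM, which is a limit of the assay and not a number. Its nearest measured neighbour, compound 1, `COc1cc2ccc(=O)oc2cc1OC(=O)c1c(-c2ccc(Cl)cc2)n[nH]c1C`, gives 17100 nM in this assay. Among the compounds with values here, the only measured step, an at least 1.4-fold higher number from compound 1 to compound 2 (0.16 log units; that floor lies within the scatter), is the same kind of exchange, a group for hydrogen on that aromatic carbon. Compound 3, `COc1cc2ccc(=O)oc2cc1OC(=O)c1c(-c2ccc([N+](=O)[O-])cc2)n[nH]c1C`, differs from compound 2 by nitro in place of hydrogen on an aromatic carbon. Nitro itself is untested here, and with one value sitting at the limit of > 25000 nM in this assay, at which 1 of the 2 values shown sits, the guidance is thin. A small gain is expected, an at least 1.3-fold lower number from compound 2 to compound 3 (0.14 log units; that floor lies within the scatter). Compound 3 is therefore estimated at 18000 nM, within a range from 7000 nM to 45000 nM.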

Compound 3, half-maximal inhibitory concentration: > 25000 nM
Compound 3: no number, only a limit (the forecaster's own chance of this, stated with the estimate: 40%); middle value at least 1.3-fold (0.14 log units) from the limit.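

In this assay compound 3 gives > 25000 nM as a limit of the assay and not a number, so 4-nitrophenyl in place of phenyl yields no readable value either. Nitro in place of chloro gives an at least 1.4-fold higher number from compound 1 to compound 3 (0.16 log units; that floor lies within the scatter) and so leaves these two groups unordered. The step from hydrogen to nitro cannot be read because both of its ends are limits: the limit of > 25000 nM in this assay, at which 2 of the 3 values shown sit.

As far as these compounds go, whether any group on this aromatic carbon can move the number clearly beyond the scatter stays open. An amine or a carboxylic acid there would test this.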